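Azetidine amide series: swapping a urea piece for a cyclohexyl amide

A few compounds are considered here, and "the series" means these few. Any claim that something is new, unique, unknown or untested is made for them only; others in the source may bear on it.

The compounds examined share a core carried on a small ring whose amide-type nitrogen bears an acyl or sulfonyl group, and they were tested in an assay on HEK293 cells for negative allosteric modulation of metabotropic glutamate receptor 5 (Homo sapiens), read by FLIPR; a lower number here means a stronger inhibitor, a higher number a weaker inhibitor. Compound 2 `COC1CCN(C(=O)N2CC(c3nc(-c4cccc(Cl)c4)no3)C2)CC1` gives only a limit of the assay, > 10000 nM, so no number is known for it. Compound 1 `Cc1cccc(-c2noc(C3CN(C(=O)C4CCC(C(F)(F)F)CC4)C3)n2)c1` likewise returns a limit, > 10000 nM. Within the data shown here, compound 3 `Cc1ccc(S(=O)(=O)N2CC(c3nc(-c4cccc(C)c4)no3)C2)cc1` is the one member with a measured number, giving 670 nM in this assay. Compound 2 therefore stands at the weak end of what is shown, sitting at the limit of > 10000 nM in this assay, at which 2 of the 3 values shown sit, together with compound 1.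

Compound 4 `CC1CCCC(C(=O)N2CC(c3nc(-c4cccc(Cl)c4)no3)C2)C1` arises from compound 2 through a change at the carbonyl carbon whose other neighbour is the amide-type nitrogen in the ring: 3-methylcyclohexyl in place of 4-methoxypiperidin-1-yl on a carbonyl carbon. Among the measured compounds shown here, no step between measured compounds in this assay is available to calibrate such a change. Since compound 2 and compound 1 both sit at the limit, and compound 1 also carries a substituted cyclohexyl on that carbonyl, the expected step from compound 2 to compound 4, an at least 1.1-fold lower number from compound 2 to compound 4 (0.04 log units; that floor lies within the scatter), is none beyond the scatter, though a limit-bound start leaves the direction open.

Compound 4 is estimated at 9000 nM, within a range of 2000 nM to 40000 nM in this assay.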

Compound 4, half-maximal inhibitory concentration: > 10000 nM
Compound 4: only a limit was reported (the forecaster's own chance of this, stated with the estimate: 55%); middle value at least 1.1-fold (0.04 log units) away from the limit.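

Compound 2 and compound 4 both return only a limit in this assay, so no step can be read for 3-methylcyclohexyl in place of 4-methoxypiperidin-1-yl on the carbonyl carbon: the limit of > 10000 nM in this assay, at which 3 of the 4 values shown sit.

The compounds shown leave open how far compound 2 and compound 4 each lie beyond that limit, and which of the two is the stronger inhibitor.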